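A few compounds are considered here, and "the series" means these few. Any claim that something is new, unique, unknown or untested is made for them only; others in the source may bear on it.

Compound 1 `N#CC1=C(N)Oc2c(N)cc3nc4ccccc4nc3c2C12C(=O)N(Cc1cnnn1-c1ccc(Cl)cc1Cl)c1ccccc12` carries a 2,4-dichlorophenyl group on an aromatic nitrogen of the shared core. In an ADME assay on HUVEC cells (Homo sapiens) for antiproliferative activity, read by MTT assay, with a stated time of 48 h (a higher number here means a weaker inhibitor, a lower number a stronger inhibitor), compound 1 gives > 50000 nM, which is a limit of the assay rather than a number. Compound 2 `N#CC1=C(N)Oc2c(N)cc3nc4ccccc4nc3c2C12C(=O)N(Cc1cnnn1-c1cc(Cl)ccc1Cl)c1ccccc12` bears 2,5-dichlorophenyl in that place instead. In this assay compound 2 gives > 50000 nM, again a limit. The step that the two limits leave unreadable from compound 1 to compound 2 therefore cannot be sized; both values rest at the limit of > 50000 nM in this assay, at which 2 of the 2 values shown sit. Compound 2 thus stands only at a limit, the same limit shown by the one other value in the series. Compound 3 `Cc1cc(C)c(-n2nncc2CN2C(=O)C3(C(C#N)=C(N)Oc4c(N)cc5nc6ccccc6nc5c43)c3ccccc32)c(C)c1` is the next member: 2,4,6-trimethylphenyl in place of 2,5-dichlorophenyl on an aromatic nitrogen. Going by the values given here, the single measured step bears on it only in that exchanging one dichlorophenyl for another left both compounds at the limit, so no readable movement is available to extrapolate from. Compound 3 is expected to remain at the limit as well, with an estimated value of 80000 nM spanning 30000 nM to 300000 nM. The implied step is estimated at a step that the limit leaves unreadable from compound 2 to compound 3.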

Compound 3, half-maximal inhibitory concentration: > 50000 nM
Compound 3: no number, only a limit (the forecaster's own chance of this, stated with the estimate: 85%); the middle value is on the limit's open side.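

Compound 3 rests at a limit rather than a number, so its steps from compound 1 and compound 2 cannot be read: the limit of > 50000 nM in this assay, at which 3 of the 3 values shown sit.
Which group on the aromatic nitrogen, if any, would give a measurable value in this assay stays open across the compounds shown.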